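Replacing the Amine Hydrogen with a Cyclopentylcarbonyl Group

A few compounds are considered here, and "the series" means these few. Any claim that something is new, unique, unknown or untested is made for them only; others in the source may bear on it.

Of the compounds shown here, two built on one shared core have been tested in an assay (strain Wistar) for displacement of a labelled ligand from adenosine receptor A1 (Rattus norvegicus), read by scintillation counting; on this read-out lower numbers stand for stronger inhibition and higher numbers for weaker inhibition. Compound 2 `Nc1nc(-c2ccccc2)nc2c1nnn2Cc1ccccc1` carries a free amino group, and in this assay compound 2 gives 5.6 nM, the lowest of the two numbers seen so far. Compound 1 `O=C(Nc1nc(-c2ccccc2)nc2c1nnn2Cc1ccccc1)C1CCCCC1` carries a cyclohexylcarbonyl group on that nitrogen, and in this assay compound 1 gives 12 nM. Among the compounds with values here, the single step between them, a 2.1-fold lower number from compound 1 to compound 2 (0.33 log units; beyond the scatter), shows that taking away the cyclohexylcarbonyl group lowers the number by a modest amount.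

Compound 3 `O=C(Nc1nc(-c2ccccc2)nc2c1nnn2Cc1ccccc1)C1CCCC1` has not yet been measured. Its change from compound 2 is cyclopentylcarbonyl in place of hydrogen on a nitrogen on an aromatic ring. This is the mirror image of the measured step, only with a smaller ring entering. That step is the only one bearing on the question, and it was modest, so a modest rise in the number is expected for compound 3 rather than none or a large one, a 1.8-fold higher number from compound 2 to compound 3 (0.25 log units; within the scatter). Compound 3 is estimated at 10 nM, with a range from 4 nM to 25 nM.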

Compound 3, inhibition constant: 2.5 nM
For compound 3 the middle estimate is 4.0-fold (0.60 log units) above the measured one; measured number below the stated range.
By their numbers in this assay, from the lowest: compound 3; then compound 2; then compound 1.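

The new result shows that a group on this nitrogen does not have to raise the number in this assay: the earlier pair alone could have suggested that the free amino group was preferred, yet cyclopentylcarbonyl in place of hydrogen gives a 2.2-fold lower number from compound 2 to compound 3 (0.35 log units; beyond the scatter). What the group carries on its carbonyl carbon therefore decides the direction of the change, since the free amino compound now sits between the two amides, with the cyclopentyl amide on the lower side and the cyclohexyl amide on the higher side. That one ring change, cyclopentyl in place of cyclohexyl on a carbonyl carbon, gives a 4.8-fold lower number from compound 1 to compound 3 (0.68 log units; beyond the scatter), and no measurement here explains why the five-membered ring gives the lower number.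

Two ring sizes cannot show whether the number keeps falling as the ring shrinks, so a cyclobutyl or cyclopropyl group on the carbonyl carbon would be the direct test of that. An open chain such as isobutyryl or a flat phenyl ring in the same place would show whether a saturated ring is needed at all.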